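The compounds below may be only part of what the source reports. "The series", "measured", "known", "first", "only" and "open" are said of these compounds alone.

Measured compounds:
compound 1 `CCOc1ccc(NC(=O)c2c(N)n[nH]c2NC)cc1` — 21800 nM
compound 2 `CCN/C(SC)=C(/C#N)C(=O)Nc1ccc(OCC)cc1` — 16400 nM
compound 3 `CCNc1[nH]nc(N)c1C(=O)Nc1ccc(OCC)cc1` — 27000 nM

All three numbers come from a functional assay on Huh-7 cells (Homo sapiens) for cytotoxicity, read by resazurin assay, with a stated time of 48 h; on this read-out lower numbers stand for stronger inhibition and higher numbers for weaker inhibition. Compound 2 gives the smallest of the three, but its gaps to compound 1 and to compound 3 both lie within the scatter, so the three compounds are not distinguished on this read-out. For the measured compounds named here, the one single-point step available, a 1.2-fold higher number from compound 1 to compound 3 (0.09 log units; within the scatter), swaps a methyl for a hydrogen on a chain carbon next to a ring nitrogen and stays within the scatter.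

Compound 4 `CCOc1ccc(NC(=O)/C(C#N)=C(\Nc2ccccc2)SC)cc1` differs from compound 2 by phenyl in place of ethyl on an amine nitrogen. Going by the values given here, no measured step exchanges an alkyl for an aryl group on this nitrogen, and the only step that touches a substituent on a nitrogen, from compound 1 to compound 3, was flat. On that basis the expected step in this assay, a 1.0-fold lower number from compound 2 to compound 4 (0.01 log units; within the scatter), is none beyond the scatter. For compound 4 the estimated value in this assay is 16000 nM, with an expected range from 6000 nM to 45000 nM.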

Compound 4, half-maximal inhibitory concentration: 25300 nM
Compound 4: middle estimate off by 1.6-fold (0.20 log units), on the low side; measured number inside the range.
By their numbers in this assay, from the lowest: compounds 2, 1, 4 and 3 (each within the scatter of the next).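

In this assay phenyl in place of ethyl on the amine nitrogen gives a 1.5-fold higher number from compound 2 to compound 4 (0.19 log units; within the scatter) and so does not separate the two compounds. This position, on an amine nitrogen whose other neighbour is the double-bonded chain carbon, therefore accepts a six-membered aromatic ring of carbon only in place of a two-carbon chain with no step beyond the scatter. The reading rests on this single pair and gives no direction for the exchange.

Going by these compounds, whether a benzyl group, a cyclohexyl group or a chain ending in a carboxylic acid on this nitrogen would give a step beyond the scatter remains open, as does the outcome of the same exchange on the core of compound 1. No measurement at hand explains the reading at this position.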